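The compounds below may be only part of what the source reports. "The series", "measured", "known", "first", "only" and "open" are said of these compounds alone.

Of the compounds shown here, three have so far been tested for their ability to slow the growth of lung cancer cells. In a functional assay on NCI-H460 cells (Homo sapiens) for antiproliferative activity, read by CCK-8 assay, with a stated time of 72 h, tested at 8 uM (a lower number here means a weaker effect, a higher number a stronger effect of the compound at the concentration tested), compound 1 `Nc1ccccc1NC(=O)c1ccc(Cn2cnc3c(Nc4cccc(OC(F)(F)F)c4)nc(Cl)nc32)cc1` gives 62.4%. Compound 2 `CCC(C)n1cnc2c(NCc3ccc(C(=O)Nc4ccccc4N)cc3)nc(Cl)nc21` gives 67.7% in this assay. Compound 3 `Nc1ccccc1NC(=O)c1ccc(COCNc2nc(Nc3ccc(-c4ccccc4)cc3)c3ncn(C4CCCC4)c3n2)cc1` gives 41.6% in this assay. Compound 2 thus carries the highest number of the three, but its gap to compound 1 lies within the usual scatter, so those two cannot be told apart; only compound 3 sits clearly lower.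

Compound 4 `Nc1ccccc1NC(=O)c1ccc(CNc2nc(Cl)nc3c2ncn3C2CCCC2)cc1` has not yet been measured. It differs from compound 2 in a single place: cyclopentyl in place of sec-butyl on an aromatic nitrogen. Within the data shown here, no pair of already measured compounds differs by a change of this kind, so there is no measured step to guide the size. The change swaps one small, uncharged carbon group for another of similar size, and so the expected step is a number 2.7 percentage points lower from compound 2 to compound 4 (within the scatter), a step that is estimated to lie within the usual scatter. Compound 4 is therefore expected to give 65% in this assay, with a range from 50% to 80%.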

Compound 4, a percentage reported as inhibition, at one concentration (the size of the read-out at that concentration, not a potency): 57.4%
For compound 4 the middle estimate is 7.6 percentage points above the measured one; measured number inside the range.
By their numbers in this assay, from the lowest: compound 3; then compounds 4, 1 and 2 (each within the scatter of the next, the first and the last beyond it).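

Among these compounds, this is the first measured step at this place, on an aromatic nitrogen of a five-membered aromatic ring: in this assay, cyclopentyl in place of sec-butyl gives a number 10.3 percentage points lower from compound 2 to compound 4 (beyond the scatter), a modest change. It shows that the read-out responds to the choice of uncharged carbon group here, even when an open group with no ring gives way to a five-membered ring of carbon only. No measurement at hand explains this step.

Among the compounds shown here, with only this one pair, it remains open whether the ring itself or some other difference between the two groups goes with the lower number. A methyl group, a longer chain such as n-hexyl, or a piperidine ring carrying an amine at this nitrogen could each extend the comparison.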